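Swapping a fluoropyridine for a methylpyrazole: expected lipophilicity

A few compounds are considered here, and "the series" means these few. Any claim that something is new, unique, unknown or untested is made for them only; others in the source may bear on it.

The measured compounds and their values:
Compound 1, `Cn1nccc1-c1cc(C(F)(F)F)ccc1[C@H]1CCOc2cc(S(=O)(=O)Nc3ncccn3)ccc21`, gives 3.7 in a physicochemical assay for lipophilicity; on this read-out higher numbers stand for higher lipophilicity and lower numbers for lower lipophilicity.
Compound 2, `O=S(=O)(Nc1ccncn1)c1ccc2c(c1)OCC[C@@H]2c1ccc(C(F)(F)F)cc1-c1ccc(F)cn1`, gives 3 in this assay.
Compound 3, `O=S(=O)(Nc1ncccn1)c1ccc2c(c1)OCC[C@@H]2c1ccc(C(F)(F)F)cc1-c1ccc(F)cn1`, gives 2.9 in this assay.

Compounds 2 and 3 share the same atoms, joined differently; the counted difference between their cores is pyrimidin-4-yl in place of pyrimidin-2-yl on a sulfonamide nitrogen. This rearrangement leaves this assay essentially untouched: the step is a number 0.10 log units lower from compound 2 to compound 3 (within the scatter). Compound 2 sits second highest of the three values, close to compound 3 and further from compound 1.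

The structural change of interest is the replacement of one aromatic ring by another on the shared carbon-only ring. From compound 3 to compound 1 the counted difference is 1-methyl-1H-pyrazol-5-yl in place of 5-fluoropyridin-2-yl on an aromatic carbon, and this change gives a number 0.80 log units higher from compound 3 to compound 1 (beyond the scatter). Compound 4, `Cn1nccc1-c1cc(C(F)(F)F)ccc1[C@H]1CCOc2cc(S(=O)(=O)Nc3ccncn3)ccc21`, is not yet measured. It differs from compound 2 by 1-methyl-1H-pyrazol-5-yl in place of 5-fluoropyridin-2-yl on an aromatic carbon; the leaving group, the entering group and the place are the same as in the step from compound 3 to compound 1, so this is the same change made on a core that differs only in how the pyrimidine is attached.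

Because a number 0.80 log units higher from compound 3 to compound 1 (beyond the scatter) was clearly beyond the scatter and a number 0.10 log units lower from compound 2 to compound 3 (within the scatter) showed that the two cores behave alike, a step of similar size is expected from compound 2 to compound 4: a number 0.80 log units higher from compound 2 to compound 4 (beyond the scatter). Compound 4 is therefore estimated at 3.8, with a plausible range from 3.4 to 4.2.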

Compound 4, distribution coefficient: 1.8
Compound 4: middle estimate off by 2.00 log units, on the high side, and the stated range ends above it.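

In this assay, 1-methyl-1H-pyrazol-5-yl in place of 5-fluoropyridin-2-yl on an aromatic carbon gives a number 1.20 log units lower from compound 2 to compound 4 (beyond the scatter) on one core but gave a number 0.80 log units higher from compound 3 to compound 1 (beyond the scatter) on the other, so the same change went in opposite directions on cores that differ only in how the pyrimidine is attached. That attachment also behaves differently with each partner: the exchange of pyrimidin-4-yl and pyrimidin-2-yl gives a number 0.10 log units lower from compound 2 to compound 3 (within the scatter) when 5-fluoropyridin-2-yl is present, but a number 1.90 log units lower from compound 1 to compound 4 (beyond the scatter) when 1-methyl-1H-pyrazol-5-yl is present, so in these four compounds neither change can be carried over as a fixed increment from one core to the other. This single set of four compounds does not show how the ring change would behave on any further core, and nothing measured here explains why the two steps differ.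

The compounds shown leave open whether this dependence on the partner group is limited to these two rings and two pyrimidine attachments. Going by these compounds, it also remains open whether the same dependence would appear with an amine, a carboxylic acid or a longer chain on the aromatic carbon where the rings were exchanged.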